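This account rests on a few compounds, and the source may have more. Where it says the series, first, only, none or still open, it means among the compounds named here.

Measured so far in a functional assay on A2780 cells (Homo sapiens) for cytotoxicity, read by MTT assay, with a stated time of 48 h; on this read-out higher numbers stand for weaker inhibition and lower numbers for stronger inhibition:
compound 1 `CCn1cc(-c2nc3ccccc3[nH]2)c(=O)c2cc(F)c(N3CCNCC3)cc21` — 800 nM
compound 2 `CCn1cc(-c2nc3ccccc3[nH]2)c(=O)c2cc(F)c(N3CCN(C)CC3)cc21` — > 5010000 nM, a limit of the assay, not a number
compound 3 `CCn1cc(-c2nc3ccc([N+](=O)[O-])cc3s2)c(=O)c2cc(F)c(N3CCNC(C)C3)c(F)c21` — 3300 nM

Compound 1 has the lowest of the two numbers shown; the nearest, compound 3, gives the higher number 3300 nM, and that gap is beyond the scatter. Compound 2 sits at the limit of > 5010000 nM in this assay, at which 1 of the 3 values shown sits, only, so the step of an at least 6200-fold higher number from compound 1 to compound 2 (3.79 log units; beyond the scatter) is known only as a lower bound, though a large one. That step concerns methyl in place of hydrogen on an amine nitrogen in a ring and does not touch the aromatic position changed here.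

Compound 4 `CCn1cc(-c2nc3ccc(N)cc3[nH]2)c(=O)c2cc(F)c(N3CCNCC3)cc21` differs from compound 1 by amino in place of hydrogen on an aromatic carbon. For the measured compounds named here, no measured step in this assay addresses a substituent on that aromatic carbon; compound 3 carries a nitro group on a different fused ring but differs from compound 1 in several further places, so no single step can be drawn from it. With nothing pointing either way, the step of a 1.1-fold higher number from compound 1 to compound 4 (0.05 log units; within the scatter) is expected to stay within the scatter. Compound 4 is therefore estimated at 900 nM, with a range from 300 nM to 3000 nM.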

Compound 4, half-maximal inhibitory concentration: 51500 nM
Beside the measured number, compound 4's estimate is 57-fold (1.76 log units) below it; the whole stated range lies below it.
By their numbers in this assay, from the lowest: compound 1; then compound 3; then compound 4. At a limit, above all of these: compound 2.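

In this assay, for the compounds shown here, the aromatic carbon on the fused system of two rings proves sensitive to substitution, which no earlier compound could show: amino in place of hydrogen gives a 64-fold higher number from compound 1 to compound 4 (1.81 log units; beyond the scatter). A single added heavy atom is therefore enough for a large step towards weaker inhibition, and compound 4 keeps the free amine nitrogen in a ring, so this step stands apart from the change at that nitrogen. Nothing measured in this set accounts for the size of the step.

As far as these compounds go, whether the step belongs to amino itself or to any substituent on this carbon stays open; a methoxy group, a fluorine or a carboxylic acid in the same place would separate the two. Also open, from the compounds shown here alone, is whether the step would carry over to the differently substituted core of compound 3.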